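This account rests on a few compounds, and the source may have more. Where it says the series, first, only, none or still open, it means among the compounds named here.

Of the compounds shown here, three with the shared core have been tested in a functional assay on KYSE-450 cells (Homo sapiens) for inhibition, read by MTT assay, with a stated time of 48 h; a higher number here means a weaker inhibitor, a lower number a stronger inhibitor. Compound 1 `CCCCC(=O)N(Cc1ccc(OC)c(O)c1)c1cc(OC)c(OC)c(OC)c1` gives 300 nM and compound 3 `CC/C=C/C(=O)N(Cc1ccc(OC)c(O)c1)c1cc(OC)c(OC)c(OC)c1` gives 72 nM, the lower of the two numbers, with compound 1 as its nearest neighbour. For compound 2 `COc1cc(NCc2ccc(Br)cc2)cc(OC)c1OC`, this assay reports only a limit, > 80000 nM. Compound 3 therefore sets the mark to compare against.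

The next candidate is compound 4 `COc1ccc(CN(C(=O)C[Se]C#N)c2cc(OC)c(OC)c(OC)c2)cc1O`, which has not yet been measured. It keeps the rest of compound 3 and changes only the group on a carbonyl carbon whose other neighbour is the amide-type nitrogen: a group of 4 heavy atoms (2 carbon, 1 nitrogen, 1 selenium; no ring) in place of a group of 4 heavy atoms (4 carbon; no ring), on a carbonyl carbon. The but-1-en-1-yl group leaves, and a group holding selenium and a triple bond enters.

Among the compounds with values here, only one measured step bears on this place. With but-1-en-1-yl in place of butyl on the carbonyl carbon, the result was a 4.2-fold lower number from compound 1 to compound 3 (0.62 log units; beyond the scatter), a modest step that goes beyond the scatter. Within the data shown here, it shows that the number responds to a change here, but no measured compound carries selenium at this carbon, so the direction is uncertain. A modest move toward a higher number seems the likeliest outcome, and the expected change is a 2.8-fold higher number from compound 3 to compound 4 (0.44 log units; beyond the scatter). Compound 4 is estimated at 200 nM, with an expected range of 40 nM to 1000 nM.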

Compound 4, half-maximal inhibitory concentration: 280 nM
Compound 4: middle estimate off by 1.4-fold (0.15 log units), on the low side, within the range that was stated.
By their numbers in this assay, from the lowest: compound 3; then compounds 4 and 1 (each within the scatter of the next). At a limit, above all of these: compound 2.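

In this assay, the group holding selenium and a triple bond, in place of but-1-en-1-yl on the carbonyl carbon, gives a 3.9-fold higher number from compound 3 to compound 4 (0.59 log units; beyond the scatter) and so shows that this position can also move toward a higher number. Measured against the butyl-bearing compound, the same group gives a 1.1-fold lower number from compound 1 to compound 4 (0.03 log units; within the scatter) and stands level with the saturated chain, so among the groups shown only but-1-en-1-yl sets itself apart here, while a chain carrying selenium and a triple bond keeps the number in the same range as butyl. The compounds shown offer nothing measured that accounts for either step.

On these data alone, what stays open is whether the selenium matters at all, since a sulfur atom in its place, or a plain carbon chain ending in a nitrile, would separate the selenium from the triple bond. As far as these compounds go, it is also open how far this position reaches beyond four heavy atoms, for instance with a longer chain, a phenyl ring or an amine on the carbon bound to the carbonyl carbon.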